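The compounds below may be only part of what the source reports. "The series", "measured", "known", "first", "only" and "open" are said of these compounds alone.

Measured so far:
compound 1 `CC(C)(C)C(=O)Nc1ccc(-c2cccc(C(=O)N[C@H]3CN[C@@H](C(=O)Nc4ccc(Cl)c(C(F)(F)F)c4)C3)c2)cn1`; in a functional assay on K562 cells (Homo sapiens) for inhibition, read by MTT assay, with a stated time of 48 h (on this read-out higher numbers stand for weaker inhibition and lower numbers for stronger inhibition), compound 1 gives 28000 nM.
compound 2 `C[C@H](NC(=O)c1ccc(-c2ccc(N)nc2)cc1)C(=O)Nc1ccc(Cl)c(C(F)(F)F)c1`; in this assay compound 2 gives 5950 nM.

Compound 2 stands at the lowest of the two numbers; compound 1 gives the higher one, and the gap between them lies beyond the scatter. Among the compounds with values here, the two differ in more than one place, so no single step between them can be read off, and their values are simply noted side by side.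

Compound 3 `CC(=O)Nc1ccc(-c2ccc(C(=O)N[C@@H](C)C(=O)Nc3ccc(Cl)c(C(F)(F)F)c3)cc2)cn1` is not yet measured in this assay. Against compound 2 it carries acetyl in place of hydrogen on a nitrogen on an aromatic ring, that is amino to acetamido, 6-aminopyridin-3-yl to 6-acetamidopyridin-3-yl. Within the data shown here, no measured pair shows this change on its own. Compound 1 also carries a substituent on the nitrogen on the aromatic ring and gives 28000 nM, but its other differences from compound 2 leave that number without a clean reading for this step. The expectation is a step from compound 2 to compound 3 of a 1.5-fold higher number from compound 2 to compound 3 (0.18 log units; within the scatter), towards a higher number, possibly beyond the scatter. Compound 3 is estimated at 9000 nM, with a range from 3000 nM to 30000 nM.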

Compound 3, half-maximal inhibitory concentration: 107000 nM
Estimate against measurement, compound 3: 12-fold (1.08 log units) below, outside the stated range (above it).
By their numbers in this assay, from the lowest: compound 2; then compound 1; then compound 3.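

In this assay, within the data shown here, acetyl in place of hydrogen on a nitrogen on an aromatic ring gives an 18-fold higher number from compound 2 to compound 3 (1.25 log units; beyond the scatter) as the first step that can be read for a single change. The position is therefore sensitive to this change, and on this read-out 6-acetamidopyridin-3-yl is clearly worse than 6-aminopyridin-3-yl on an otherwise unchanged structure. Compound 1 also carries a substituent on that nitrogen but differs from compound 2 in more than one place, so it cannot show whether the same step holds on its core, and no measurement shown bears on why this step is so large.

As far as these compounds go, it remains open whether the higher number belongs to the acetyl group specifically or follows from any replacement of hydrogen on this nitrogen, a question that a single methyl or a dimethylamino group at the same place would help to settle. From the compounds shown here alone, it is also open how a longer acyl chain such as propanoyl, or a carboxylic acid or hydroxyl in place of the amino group, would read at this position.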